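Aryl swap on the carbonyl: compound 3 to compound 4

The compounds below may be only part of what the source reports. "The series", "measured", "known", "first", "only" and "open" are said of these compounds alone.

Compound 1 `CN(C(=O)NC(=O)c1ccc(F)c(F)c1)c1nc(C(F)(F)F)c(C(=O)N/N=C/c2ccc(C(F)(F)F)cc2)s1` and compound 2 `CN(C(=O)NC(=O)c1ccc(Cl)cc1Cl)c1nc(C(F)(F)F)c(C(=O)N/N=C/c2ccc(C(F)(F)F)cc2)s1` share one core; compound 3 `CN(C(=O)NC(=O)c1ccc(F)c(F)c1)c1nc(C(F)(F)F)c(C(=O)N/N=C/c2cc(C(F)(F)F)cc(C(F)(F)F)c2)s1` and the not yet measured compound 4 `CN(C(=O)NC(=O)c1ccc(Cl)cc1Cl)c1nc(C(F)(F)F)c(C(=O)N/N=C/c2cc(C(F)(F)F)cc(C(F)(F)F)c2)s1` share another, and the difference between the two cores is not broken down here. In a functional assay on HeLa cells (Homo sapiens) for inhibition, read by MTT assay, with a stated time of 72 h (a higher number here means a weaker inhibitor, a lower number a stronger inhibitor), compound 1 gives 5.1 ug/mL, compound 2 gives 7.99 ug/mL and compound 3 gives 4.45 ug/mL. Among the compounds with values here, the three numbers lie close together, and no compound stands apart from the others in this assay. The change from compound 1 to compound 2 is 2,4-dichlorophenyl in place of 3,4-difluorophenyl on a carbonyl carbon and it made a 1.6-fold higher number from compound 1 to compound 2 (0.19 log units; within the scatter). The change planned on the second core is 2,4-dichlorophenyl in place of 3,4-difluorophenyl on a carbonyl carbon; the surroundings of the place are the same in both pairs, so this is the same change carried onto the core of compound 3. Within the data shown here, a step of about the same small size is expected, a 1.6-fold higher number from compound 3 to compound 4 (0.20 log units; within the scatter), because a 1.6-fold higher number from compound 1 to compound 2 (0.19 log units; within the scatter) is the only measured instance of the change. Compound 4 is therefore estimated at 7 ug/mL in this assay, with a range from 3.5 ug/mL to 14 ug/mL.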

Compound 4, half-maximal inhibitory concentration: > 100 ug/mL
Compound 4 ended at the assay's limit (the forecaster's own chance of this, stated with the estimate: 5%); at least 14-fold (1.15 log units) between middle value and limit.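

In this assay compound 4 gives > 100 ug/mL, which is a limit of the assay and not a number. This gives an at least 22-fold higher number from compound 3 to compound 4 (1.35 log units; beyond the scatter), so 2,4-dichlorophenyl in place of 3,4-difluorophenyl on a carbonyl carbon does not carry over at the same size between these two cores: the same change on two cores in this assay, a 1.6-fold higher number (0.19 log units; within the scatter) from compound 1 to compound 2 and an at least 22-fold higher number (1.35 log units; beyond the scatter) from compound 3 to compound 4, at least 14-fold (1.15 log units) apart, beyond the scatter of two such steps. The two pairs show that the size of this step depends on the core here, but they do not show which part of the difference between the cores is responsible or how large the step on the core of compound 3 really is, and they set no rule for the wider series.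

Open, on these data alone, is whether a phenyl ring carrying a single chlorine, or a methoxy group, on the carbonyl carbon would stay close to compound 3 or follow compound 4. Also open, as far as these compounds go, is whether a pyridine ring in place of the aryl group on the carbonyl carbon would tolerate the core of compound 3.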